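A few compounds are considered here, and "the series" means these few. Any claim that something is new, unique, unknown or untested is made for them only; others in the source may bear on it.

Measured so far, in a functional assay on cardiac atrium for agonist activity at histamine H2 receptor (Cavia porcellus); a higher number here means a more potent compound, by a factor of ten per unit of this negative logarithm, a lower number a less potent compound:

compound 1, `N=C(NCCCc1c[nH]cn1)NCCSC(c1ccccc1)c1ccccn1`: 6.6
compound 2, `N=C(NCCCc1c[nH]cn1)NCCCC(c1ccc(F)cc1)c1ccccn1`: 6.87
compound 3, `N=C(NCCCc1c[nH]cn1)NCCC(c1ccccc1)c1ccccn1`: 7.39

All three share the same core and differ only in the linker between the guanidine part and the two aromatic rings, and in whether one of those rings carries a fluorine. Compound 3 stands highest of the three in this assay; its gap to compound 2 is beyond the usual scatter, and its gap to compound 1 is larger still, also beyond the scatter. For the measured compounds named here, none of the three measured compounds differs from another in just one place, so no single clean step among them can be read off.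

Compound 4, `N=C(NCCCc1c[nH]cn1)NCCC(c1cccc(F)c1)c1ccccn1`, keeps the linker of compound 3 and differs from it by one change: fluoro in place of hydrogen on an aromatic carbon. Among the measured compounds there is no matched pair that isolates such a fluorine, so the expected step is not anchored by a direct precedent. Compound 4 is expected to give 7.3, with a likely range from 6.8 to 7.8. This corresponds to an expected step of a number 0.09 log units lower from compound 3 to compound 4 (within the scatter), essentially none beyond the scatter.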

Compound 4, negative logarithm of the half-maximal effective concentration: 7.88
Beside the measured number, compound 4's estimate is 0.58 log units below it; the whole stated range lies below it.
By their numbers in this assay, from the lowest: compounds 1 and 2 (each within the scatter of the next); then compound 3; then compound 4.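

Putting fluoro in place of hydrogen on an aromatic carbon, meta to a large group, gives a number 0.49 log units higher from compound 3 to compound 4 (beyond the scatter) in this assay. For the compounds shown here, this is the first step that changes one place only, and it shows that this ring position accepts a fluorine without any loss of potency. A single added atom here is enough to carry the number past the usual scatter, although the step is modest. No measurement at hand bears on the reason for this gain. Going by these compounds, whether a chloro, a methyl or a methoxy group at the same ring position would give a similar step stays open. So does whether fluoro would bring a gain at the other carbons of this phenyl ring.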